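The source may hold more compounds than are shown below. What is called first, only, known or untested is meant among the compounds shown, and "the series" means these compounds.

Compound 1 `Cc1ccc(NC2=CC(=O)c3nc4n(c3C2=O)[C@H]2OC[C@@H](O)[C@H]2OC4)cc1` holds the lowest of the three numbers measured in a functional assay on HeLa cells (Homo sapiens) for inhibition, read by sulforhodamine B assay (a lower number here means a stronger inhibitor, a higher number a weaker inhibitor), where compound 1 gives 3860 nM. Compound 2 `O=C1C(Nc2cccc(Cl)c2)=CC(=O)c2c1nc1n2[C@H]2OC[C@@H](O)[C@H]2OC1` gives 7970 nM in this assay, and compound 3 `CCOc1ccc(NC2=CC(=O)c3c(nc4n3[C@H]3OC[C@@H](O)[C@H]3OC4)C2=O)cc1` gives 14400 nM. Within the data shown here, the one step recorded between neighbours, a 1.8-fold higher number from compound 2 to compound 3 (0.26 log units; within the scatter), exchanges one aryl group on the amine nitrogen for another and stays within the scatter. Compound 4 `O=C1C=C(Nc2ccccc2)C(=O)c2c1nc1n2[C@H]2OC[C@@H](O)[C@H]2OC1` is related to compound 1 by a single change: hydrogen in place of methyl on an aromatic carbon. Among the measured compounds shown here, no measured pair shows exactly this change; the nearest comparison is between compound 1 and compound 3, both carrying a group on an aromatic carbon para to a large group, where the 4-ethoxyphenyl of compound 3 goes with the higher number. The step from compound 2 to compound 3 offers the only measured size for a change on this ring and is small. Compound 4 is therefore expected to differ only modestly, by a 1.4-fold higher number from compound 1 to compound 4 (0.15 log units; within the scatter). On this basis compound 4 is estimated at 5500 nM, with a range from 2500 nM to 13000 nM.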

Compound 4, half-maximal inhibitory concentration: 5620 nM
Estimate against measurement, compound 4: 1.0-fold (0.01 log units) below; the range from low to high includes it.
By their numbers in this assay, from the lowest: compounds 1, 4, 2 and 3 (each within the scatter of the next, the first and the last beyond it).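

Taking the methyl off the 4-methylphenyl group, at the aromatic carbon para to a large group, gives in this assay a direct reading of this position for the first time: a 1.5-fold higher number from compound 1 to compound 4 (0.16 log units; within the scatter). The methyl can therefore be replaced by hydrogen here without a step beyond the scatter, although this rests on a single pair and says nothing about other groups at this carbon. Nothing available explains the size of this step.

The compounds shown leave open how an amine, a carboxylic acid or a longer alkyl chain on the same aromatic carbon would read in this assay. They also leave open what would follow if a cyclohexyl group took the place of the phenyl on the amine nitrogen.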